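Notes on the thiophen-2-yl to thiophen-3-yl swap

The source may report more compounds than this note shows. Statements on the series, on what has been measured and on what is new or still open speak of the compounds shown alone.

Measured so far in a functional assay on T47D cells (Homo sapiens) for inhibition, read by CCK-8 assay and cell counting, with a stated time of 2 days; a higher number here means a weaker inhibitor, a lower number a stronger inhibitor
compound 1 `O=C(/C=C/c1ccco1)c1ccccc1OCC1CO1` gives 19400 nM
compound 2 `O=C(/C=C/c1cccs1)c1cccc(OCC2CO2)c1` gives 14600 nM
compound 3 `O=C(/C=C/c1cccs1)c1ccc(OCC2CO2)cc1` gives 17800 nM

Compound 3 at 17800 nM stands within the scatter of both other measured compounds, so the three values show no order. Compound 4 `O=C(/C=C/c1ccsc1)c1ccc(OCC2CO2)cc1` carries thiophen-3-yl in place of thiophen-2-yl on a double-bonded chain carbon bound to a double-bonded chain carbon. Among the compounds with values here, no measured pair isolates this change, so any expectation rests on the narrow spread of the three values. The expected step in this assay is a 1.1-fold lower number from compound 3 to compound 4 (0.05 log units; within the scatter) and is not expected to go beyond the scatter. For compound 4 the estimated value is 16000 nM, with an expected range from 8000 nM to 30000 nM (estimate).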

Compound 4, half-maximal inhibitory concentration: 10600 nM
Beside the measured number, compound 4's estimate is 1.5-fold (0.18 log units) above it; the measured number falls inside the stated range.
By their numbers in this assay, from the lowest: compounds 4, 2, 3 and 1 (each within the scatter of the next).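

Within the data shown here, compound 4 gives the first pair that isolates a single change: in this assay, thiophen-3-yl in place of thiophen-2-yl on a double-bonded chain carbon gives a 1.7-fold lower number from compound 3 to compound 4 (0.23 log units; within the scatter). At this place, the two thiophene attachments therefore cannot be told apart in this assay. Nothing available gives a reason for the step.

On these data alone, it remains open whether the same swap on the core of compound 2 would also stay within the scatter. As far as these compounds go, it is also open whether a pyridine ring or an amine at this place would give a step beyond it.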